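Trimethoxyphenyl ureas: nitro to fluoro on the aryl

The compounds below may be only part of what the source reports. "The series", "measured", "known", "first", "only" and "open" are said of these compounds alone.

compound 1 `COc1ccc(N(C)C(=O)N(C)c2cc(OC)c(OC)c(OC)c2)cc1`: >= 125000 nM
compound 2 `COc1cc(NC(=O)Nc2ccc([N+](=O)[O-])cc2)cc(OC)c1OC`: 70800 nM

Among the measured compounds shown here, in a functional assay on Daoy cells (Homo sapiens) for cytotoxicity, read by MTT assay, with a stated time of 72 h (on this read-out higher numbers stand for weaker inhibition and lower numbers for stronger inhibition), compound 2 gives 70800 nM, the only number among the values shown. Compound 1 reaches only a limit of the assay, (the limit of >= 125000 nM in this assay, at which 1 of the 2 values shown sits). Compound 3 `COc1cc(NC(=O)Nc2ccc(F)cc2)cc(OC)c1OC` differs from compound 2 by fluoro in place of nitro on an aromatic carbon. For the measured compounds named here, no step between measured compounds is available, so the expected step of a 1.4-fold higher number from compound 2 to compound 3 (0.15 log units; within the scatter) in this assay is a modest weakening, within or just beyond the scatter. Compound 3 is estimated at 100000 nM (25000 nM to 200000 nM), with a real chance that only a limit is reported.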

Compound 3, half-maximal inhibitory concentration: 104000 nM
The estimate for compound 3 lay 1.0-fold (0.02 log units) below the measured number, and the stated range covers the measured number.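

In this assay, fluoro in place of nitro on an aromatic carbon, para to a large group, gives a 1.5-fold higher number from compound 2 to compound 3 (0.17 log units; within the scatter). At this position, the two groups are therefore not separated by this pair, even though nitro and fluoro differ in heavy atoms and hydrogen-bond acceptors. Nothing shown gives a cause for this step. As far as these compounds go, whether an amine or a carboxylic acid on the same carbon would move the number beyond the scatter remains open. Also open, from the compounds shown here alone, is how a methoxy group there would read against fluoro.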